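A few compounds are considered here, and "the series" means these few. Any claim that something is new, unique, unknown or untested is made for them only; others in the source may bear on it.

Compound 1, `Cc1csc(-c2cc(C(O)(C(F)(F)F)C(F)(F)F)cnc2N2CCN(S(=O)(=O)c3ccc(N)nc3)CC2)c1`, was examined in an ADME assay (liver) for metabolic stability, with Liver microsome (Homo sapiens) as the target, using microsomes and NADPH, with a stated time of 30 min, tested at 1 uM (a lower number here means slower removal, a higher number faster removal of the compound), where compound 1 gives 29 mL.min-1.g-1. Two companions share its core and differ only in the group on the aromatic carbon that carries the 4-methylthiophen-2-yl ring. Compound 2, `Nc1ccc(S(=O)(=O)N2CCN(c3ncc(C(O)(C(F)(F)F)C(F)(F)F)cc3-c3cccnc3)CC2)cn1`, gives 17 mL.min-1.g-1, and compound 3, `COc1ccc(-c2cc(C(O)(C(F)(F)F)C(F)(F)F)cnc2N2CCN(S(=O)(=O)c3ccc(N)nc3)CC2)cn1`, gives 25 mL.min-1.g-1. Among these three numbers compound 1 has the highest, but the steps to both companions stay within the scatter: a 1.7-fold lower number from compound 1 to compound 2 (0.23 log units; within the scatter) and a 1.2-fold lower number from compound 1 to compound 3 (0.06 log units; within the scatter). Between the two companions the step is likewise small, a 1.5-fold higher number from compound 2 to compound 3 (0.17 log units; within the scatter).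

Compound 4, `Nc1ccc(S(=O)(=O)N2CCN(c3ncc(C(O)(C(F)(F)F)C(F)(F)F)cc3-c3cccc4[nH]ncc34)CC2)cn1`, makes a further change at the same place: 1H-indazol-4-yl in place of 4-methylthiophen-2-yl on an aromatic carbon. The two measured steps that bear on it, the exchanges leading to compound 2 and to compound 3, both replaced the 4-methylthiophen-2-yl ring and both left the number essentially where it was. No exchange at this position has yet moved the read-out beyond the scatter, so for compound 4 no step beyond the scatter is expected in this assay, perhaps a slight drift toward the lower side seen for compound 2. The step expected is a 1.3-fold lower number from compound 1 to compound 4 (0.12 log units; within the scatter). Compound 4 is therefore estimated at 22 mL.min-1.g-1, within a range from 10 mL.min-1.g-1 to 45 mL.min-1.g-1.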

Compound 4, intrinsic clearance in microsomes: 42 mL.min-1.g-1
Compound 4: the middle estimate sits 1.9-fold (0.28 log units) below what was measured; the range from low to high includes it.
By their numbers in this assay, from the lowest: compounds 2, 3, 1 and 4 (each within the scatter of the next, the first and the last beyond it).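

In this assay, going by these compounds alone, this position now shows a step beyond the scatter for the first time, a 2.5-fold higher number from compound 2 to compound 4 (0.39 log units; beyond the scatter), while a 1.4-fold higher number from compound 1 to compound 4 (0.16 log units; within the scatter) and a 1.7-fold higher number from compound 3 to compound 4 (0.23 log units; within the scatter) both remain within it. The separation therefore holds only against the pyridin-3-yl group of compound 2, and the exchange of 4-methylthiophen-2-yl for 1H-indazol-4-yl, which adds a six-membered aromatic ring and a hydrogen-bond donor, does not by itself set compound 4 apart from compound 1. No measurement offered here accounts for the step from compound 2 to compound 4, so it stands as an observation without an explanation.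

The compounds shown leave open whether the hydrogen-bond donor or the second ring of 1H-indazol-4-yl goes with the higher number, a question that a methyl group on the indazole nitrogen or a plain phenyl ring at this place would begin to address. They also leave open how an amine or a carboxylic acid on the ring at this place would read, and whether the step would recur with a different group in place of the 2,2,2-trifluoro-1-hydroxy-1-(trifluoromethyl)ethyl group.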